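A few compounds are considered here, and "the series" means these few. Any claim that something is new, unique, unknown or untested is made for them only; others in the source may bear on it.

The measured compounds:
compound 1, `CN(C)S(=O)(=O)c1ccccc1Nc1cc(-c2ccc3ccn(C)c3c2)c2nccnc2c1`, which in an assay for inhibition of 6-phosphofructo-2-kinase/fructose-2,6-bisphosphatase 3 (Homo sapiens), read by ADP-Glo, with a stated time of 2 h (on this read-out higher numbers stand for weaker inhibition and lower numbers for stronger inhibition), gives 94 nM;
compound 2, `Cn1ccc2ccc(-c3cc(Nc4ccccc4S(=O)(=O)Nc4cncnc4)cc4nccnc34)cc21`, which in this assay gives 1690 nM;
compound 3, `CN1CCC(NC(=O)c2ccncc2Nc2cc(-c3ccc4ccn(C)c4c3)c3nccnc3c2)CC1`, which in this assay gives 38 nM.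

Compound 3 holds the lowest number of the three; compound 1 is its nearest neighbour and compound 2 lies furthest away, both gaps beyond the scatter. Compound 4, `CC(=O)N1CC(NC(=O)c2ccncc2Nc2cc(-c3ccc4ccn(C)c4c3)c3nccnc3c2)C1`, differs from compound 3 in one place: 1-acetylazetidin-3-yl in place of 1-methylpiperidin-4-yl on an amide-type nitrogen. Among the measured compounds shown here, the one measured step, an 18-fold higher number from compound 1 to compound 2 (1.25 log units; beyond the scatter), concerns the group on a sulfonyl sulfur of compound 1 and does not touch the amide-type nitrogen changed here, so no measured step bears directly on the move from compound 3 to compound 4. With nothing to anchor the change, a small shift toward a higher number is expected, close to the scatter. Compound 4 is therefore estimated at 65 nM in this assay, with a range from 20 nM to 220 nM, which means an expected step of a 1.7-fold higher number from compound 3 to compound 4 (0.23 log units; within the scatter).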

Compound 4, half-maximal inhibitory concentration: 73 nM
Compound 4: middle estimate off by 1.1-fold (0.05 log units), on the low side; measured number inside the range.
By their numbers in this assay, from the lowest: compounds 3, 4 and 1 (each within the scatter of the next, the first and the last beyond it); then compound 2.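

In this assay, placing 1-acetylazetidin-3-yl in place of 1-methylpiperidin-4-yl on the amide-type nitrogen gives a 1.9-fold higher number from compound 3 to compound 4 (0.28 log units; within the scatter), so the two compounds cannot be told apart on this read-out. Among the compounds shown here, this is the first view of this position, as the earlier step, an 18-fold higher number from compound 1 to compound 2 (1.25 log units; beyond the scatter), concerned a group on a sulfonyl sulfur. It shows that a four-membered ring carrying an acetyl group and a six-membered ring carrying a methyl group can occupy this place with no difference beyond the scatter.

The compounds shown do not separate ring size from the acetyl group, a question that 1-acetylpiperidin-4-yl or 1-methylazetidin-3-yl on the same nitrogen would address. They also leave open how an open chain such as 2-methoxyethyl or a carboxylic acid would fare here. No evidence is available that accounts for this result.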